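Benzylselanyl in place of methylsulfanyl across two cores

This account rests on a few compounds, and the source may have more. Where it says the series, first, only, none or still open, it means among the compounds named here.

Compound 2 `CS/C(=N\C(=O)c1cccs1)NC(=O)c1cccs1` and compound 1 `O=C(/N=C(/NC(=O)c1cccs1)[Se]Cc1ccccc1)c1cccs1` share one core. In a functional assay on K562 cells (Homo sapiens) for cytotoxicity, read by MTT assay, with a stated time of 72 h (a higher number here means a weaker inhibitor of growth, a lower number a stronger inhibitor of growth), compound 2 gives only a limit, > 100000 nM. In this assay compound 1 gives 58500 nM. The change between them is a group of 8 heavy atoms (7 carbon, 1 selenium; one six-membered aromatic ring of carbon only) in place of a group of 2 heavy atoms (1 carbon, 1 sulfur; no ring), on a carbon with a double bond to nitrogen and the step is an at least 1.7-fold lower number from compound 2 to compound 1 (0.23 log units; that floor lies within the scatter); its floor rests on (the limit of > 100000 nM in this assay, at which 2 of the 3 values shown sit). Compound 3 `CS/C(=N\C(=O)c1cnc2ccccc2c1)NC(=O)c1cnc2ccccc2c1` carries another core; the difference between the two cores is not broken down here. In this assay compound 3 gives only a limit, > 100000 nM. Compound 4 `O=C(/N=C(/NC(=O)c1cnc2ccccc2c1)[Se]Cc1ccccc1)c1cnc2ccccc2c1` is not yet measured; it differs from compound 3 by a group of 8 heavy atoms (7 carbon, 1 selenium; one six-membered aromatic ring of carbon only) in place of a group of 2 heavy atoms (1 carbon, 1 sulfur; no ring), on a carbon with a double bond to nitrogen, the same kind of change made from compound 2 to compound 1, at a place described in the same words. For compound 4 a step of an at least 1.4-fold lower number from compound 3 to compound 4 (0.15 log units; that floor lies within the scatter) is expected, because the same change gave an at least 1.7-fold lower number from compound 2 to compound 1 (0.23 log units; that floor lies within the scatter). Compound 4 is estimated at 70000 nM, expected to fall between 30000 nM and 150000 nM.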

Compound 4, concentration for total growth inhibition: 72600 nM
Estimate against measurement, compound 4: 1.0-fold (0.02 log units) below; low and high end bracket the measured number.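

In this assay, benzylselanyl in place of methylsulfanyl on the second core gives an at least 1.3-fold lower number from compound 3 to compound 4 (0.13 log units; that floor lies within the scatter), and the comparison with the first core reads: the same change on two cores in this assay, an at least 1.7-fold lower number (0.23 log units; that floor lies within the scatter) from compound 2 to compound 1 and an at least 1.3-fold lower number (0.13 log units; that floor lies within the scatter) from compound 3 to compound 4; the limit leaves it open whether they differ. Both steps rest on the same ceiling: the limit of > 100000 nM in this assay, at which 2 of the 4 values shown sit. The result therefore shows no conflict in carrying the change from one core to the other, but it does not show a step beyond the scatter on either core, nor that the size of the step carries over.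

Open, as far as these compounds go, is how a benzylsulfanyl or a methylselanyl group on the same carbon would compare, which would separate the contribution of the selenium from that of the ring. Also open, from the compounds shown here alone, is whether an amine or a longer alkyl chain at this place would give a value clear of the limit.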